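Ring expansion of a cyclic amine: compound 1 to compound 3

The source may report more compounds than this note shows. Statements on the series, on what has been measured and on what is new or still open speak of the compounds shown alone.

Measured so far in a functional assay on MV4-11 cells (Homo sapiens) for inhibition, read by luminescence and CellTiter-Glo, with a stated time of 72 h; on this read-out lower numbers stand for stronger inhibition and higher numbers for weaker inhibition:
- compound 1 `COc1ccccc1-c1ccnc(Nc2ccc3c(N4CCNCC4)cc(=O)oc3c2)n1`: 1340 nM
- compound 2 `COc1cc(F)ccc1-c1nc(Nc2ccc3c(N4CCN(C)CC4)c(C(C)=O)c(=O)oc3c2)ncc1Cl`: 1390 nM

Compound 1 has the lower of the two numbers, but compound 2 sits so close to it that the two values lie within the usual scatter of this assay, so nothing separates them. Among the measured compounds shown here, no step between two measured compounds differing in one place has been recorded, so there is no measured guide for the change at hand.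

Compound 3 `COc1ccccc1-c1ccnc(Nc2ccc3c(N4CCCNCC4)cc(=O)oc3c2)n1` differs from compound 1 in a single spot: 1,4-diazepan-1-yl in place of piperazin-1-yl on an aromatic carbon. The cyclic amine grows by one ring atom while keeping the same count of hydrogen-bond donors and acceptors and no net charge, and the rest of the molecule is untouched.

For the measured compounds named here, with no comparable step on record, the size of this change can only be guessed. A change of one ring atom in a side group of this kind is expected to move this assay by no more than the scatter, in either direction. Compound 3 is therefore estimated at 1500 nM, within a range from 500 nM to 4500 nM. The expected step from compound 1 to compound 3 is a 1.1-fold higher number from compound 1 to compound 3 (0.05 log units; within the scatter), that is, essentially no change beyond the scatter.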

Compound 3, half-maximal inhibitory concentration: 1680 nM
The estimate for compound 3 lay 1.1-fold (0.05 log units) below the measured number; measured number inside the range.
By their numbers in this assay, from the lowest: compounds 1, 2 and 3 (each within the scatter of the next).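

In this assay, among the compounds shown here, the swap of piperazin-1-yl for 1,4-diazepan-1-yl amounts to a 1.3-fold higher number from compound 1 to compound 3 (0.10 log units; within the scatter) and gives the first measured step at this position, on an aromatic carbon of the ring that carries the ring oxygen. It shows that the cyclic amine here can grow from a six-membered to a seven-membered ring, with the same counts of hydrogen-bond donors and acceptors, and the read-out cannot distinguish the result from repeated measurements of compound 1. No measured information is at hand to explain why these two rings give values so alike.

This single step says nothing about how far the position tolerates other changes, such as a smaller ring like 3-aminopyrrolidin-1-yl, a morpholin-4-yl ring with an oxygen in place of the second nitrogen, or an open-chain amine like 2-aminoethylamino. It also leaves open whether 1,4-diazepan-1-yl would behave the same way on the differently substituted core of compound 2, where the amine ring sits in a different setting.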